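The source may hold more compounds than are shown below. What is called first, only, known or untested is meant among the compounds shown, and "the series" means these compounds.

The measured compounds:
compound 1, `CC(=O)Nc1cccc2c(=O)n(O)c(=O)[nH]c12`, gives 38 nM in an assay on isolated protein for inhibition of Flap endonuclease 1 (Homo sapiens); on this read-out lower numbers stand for stronger inhibition and higher numbers for weaker inhibition;
compound 2, `CNC(=O)c1nc(-c2cccs2)[nH]c(=O)c1O`, gives 12000 nM in this assay.

Compound 2 holds the higher of the two numbers, and its gap to compound 1 lies beyond the scatter. Compound 3, `O=C(NCCO)c1nc(-c2cccs2)[nH]c(=O)c1O`, differs from compound 2 by hydroxymethyl in place of hydrogen on a saturated chain carbon bound to an amide-type nitrogen. For the measured compounds named here, no step of this kind has been measured here, so the expectation rests on compound 2 alone. The change is expected to stay within the scatter, or at most to nudge the number modestly downward: a 1.3-fold lower number from compound 2 to compound 3 (0.12 log units; within the scatter). Compound 3 is therefore estimated at 9000 nM, with a range from 3000 nM to 30000 nM.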

Compound 3, half-maximal inhibitory concentration: 4000 nM
Estimate against measurement, compound 3: 2.3-fold (0.35 log units) above; the measured number falls inside the stated range.
By their numbers in this assay, from the lowest: compound 1; then compound 3; then compound 2.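

In this assay, hydroxymethyl in place of hydrogen on a saturated chain carbon bound to an amide-type nitrogen gives a 3.0-fold lower number from compound 2 to compound 3 (0.48 log units; beyond the scatter), so this position responds to change. Going from methylcarbamoyl to (2-hydroxyethyl)carbamoyl is a modest gain beyond the scatter, and the longer chain is tolerated here. No measurement at hand accounts for this gain. Going by these compounds, whether an ethyl group would do the same as 2-hydroxyethyl stays open. So does the effect of a longer chain, an amine or a carboxylic acid in its place.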